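The source may hold more compounds than are shown below. What is called first, only, known or untested is meant among the compounds shown, and "the series" means these compounds.

In a physicochemical assay for solubility, read by LC-MS, in phosphate buffer, with a stated time of 24 h, at pH 6.8 (a higher number here means a more soluble compound, a lower number a less soluble compound), two compounds have been measured so far. Compound 1 (`CCC(=O)N[C@@H](C)c1ccc(NC(=O)N2CC(c3cccnc3)C2)cc1`) gives 700000 nM and compound 2 (`C[C@H](NC(=O)C1CCOCC1)c1ccc(NC(=O)N2CC(c3ccc(N)nc3)C2)cc1`) gives 310000 nM as the lower of the two numbers, a gap that lies beyond the scatter. Compound 3 (`CCC(=O)N[C@@H](C)c1ccc(NC(=O)N2CC(c3ccc(N)nc3)C2)cc1`) has not yet been measured. It differs from compound 2 in one place, on a carbonyl carbon whose other neighbour is an amide-type nitrogen, where ethyl stands in place of oxan-4-yl (ethyl in place of oxan-4-yl on a carbonyl carbon). For the measured compounds named here, no measured pair shows this change alone. Compound 1 also carries propanoylamino and gives 700000 nM in this assay so a small upward step is expected, perhaps not beyond the scatter. The expected step is a 1.4-fold higher number from compound 2 to compound 3 (0.13 log units; within the scatter) in this measurement. For compound 3 the estimated value is 420000 nM with an expected range from 170000 nM to 900000 nM in this assay once it is measured.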

Compound 3, solubility: 760000 nM
For compound 3 the middle estimate is 1.8-fold (0.26 log units) below the measured one; the range from low to high includes it.
By their numbers in this assay, from the lowest: compound 2; then compounds 1 and 3 (each within the scatter of the next).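

In this assay, the place on a carbonyl carbon whose other neighbour is an amide-type nitrogen now has its first single-change reading: ethyl in place of oxan-4-yl gives a 2.5-fold higher number from compound 2 to compound 3 (0.39 log units; beyond the scatter). Amino in place of hydrogen on an aromatic carbon also has its first reading, a 1.1-fold higher number from compound 1 to compound 3 (0.04 log units; within the scatter), so with ethyl on the carbonyl carbon this second change gives no difference that stands clear of the scatter. Nothing measured here bears on why either step has the size it has.

This one pair cannot separate the ring oxygen from the ring itself or from the number of heavy atoms; a cyclohexyl group or a butyl chain on that carbonyl carbon would bear on this. From the compounds shown here alone, whether amino in place of hydrogen reads the same with oxan-4-yl on the carbonyl carbon also remains open.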